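From Butoxy to Fluoro in a Flat Series

The source may report more compounds than this note shows. Statements on the series, on what has been measured and on what is new or still open speak of the compounds shown alone.

In a functional assay on KB cells (Homo sapiens) for inhibition (on this read-out higher numbers stand for weaker inhibition and lower numbers for stronger inhibition), compound 1 `COC[C@H]1OC(n2c(Cl)nc3cc(Cl)c(Cl)cc32)[C@H](O)[C@@H]1O` gives 90000 nM, compound 2 `CCOC[C@H]1OC(n2c(Cl)nc3cc(Cl)c(Cl)cc32)[C@H](O)[C@@H]1O` gives 80000 nM and compound 3 `CCCCOC[C@H]1OC(n2c(Cl)nc3cc(Cl)c(Cl)cc32)[C@H](O)[C@@H]1O` gives 60000 nM. Compound 3 therefore stands within the scatter of both other compounds. These three share a core and differ only in the chain carried on the oxygen. The measured steps are a 1.1-fold lower number from compound 1 to compound 2 (0.05 log units; within the scatter), a 1.3-fold lower number from compound 2 to compound 3 (0.12 log units; within the scatter) and a 1.5-fold lower number from compound 1 to compound 3 (0.18 log units; within the scatter), and none of them exceeds the scatter.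

Compound 4 `O[C@@H]1[C@@H](CF)OC(n2c(Cl)nc3cc(Cl)c(Cl)cc32)[C@@H]1O` departs from compound 3 by a larger change: fluoro in place of butoxy on a saturated chain carbon bound to a saturated ring carbon. In words, this is fluoro in place of butoxy on a saturated chain carbon bound to a saturated ring carbon. Among the measured compounds shown here, no measured step removes the oxygen or introduces fluoro, so the data offer no direct precedent. The nearest evidence is the shortening of the chain, and the largest such step, a 1.5-fold lower number from compound 1 to compound 3 (0.18 log units; within the scatter), stays within the scatter. On that basis, no shift beyond the scatter is expected in this assay, although the uncertainty is wide and the direction is open. The expected change is a 1.2-fold higher number from compound 3 to compound 4 (0.07 log units; within the scatter). For compound 4 the estimated value is 70000 nM, with an expected range from 25000 nM to 160000 nM.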

Compound 4, half-maximal inhibitory concentration: > 100000 nM
Compound 4 ended at the assay's limit; the forecaster's own chance of this, stated with the estimate: 20%; at least 1.4-fold (0.15 log units) between middle value and limit.
By their numbers in this assay, from the lowest: compounds 3, 2 and 1 (each within the scatter of the next). At a limit, above all of these: compound 4.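

In this assay, the value of compound 4 is a limit of the assay and not a number: the limit of > 100000 nM in this assay, at which 1 of the 4 values shown sits.

Among the compounds shown here, this is what the earlier compounds could not show: methoxy, ethoxy and butoxy all gave readable numbers, and changing the length of the chain never moved the read-out beyond the scatter, whereas replacing the whole chain with fluoro on this saturated chain carbon is the first change here to reach the limit. Read as floors, the steps are an at least 1.6-fold higher number from compound 3 to compound 4 (0.22 log units; that floor lies within the scatter), an at least 1.2-fold higher number from compound 2 to compound 4 (0.09 log units; that floor lies within the scatter) and an at least 1.1-fold higher number from compound 1 to compound 4 (0.04 log units; that floor lies within the scatter), so the limit alone does not place compound 4 beyond the scatter of any of the other three compounds.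

Going by these compounds, how far compound 4 truly lies from the compounds with an oxygen-linked chain therefore stays open, and so does whether the result follows the loss of the ether oxygen, the loss of the chain or the arrival of fluorine. A hydroxyl, an amine or a chlorine on the same carbon, or an oxygen-linked chain longer than butoxy, would help to separate these readings.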